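The compounds below may be only part of what the source reports. "The series", "measured", "known", "first", "only" and "open" are said of these compounds alone.

In a physicochemical assay for solubility, read by HPLC, in phosphate buffer, measured as kinetic solubility, with a stated time of 24 h, at pH 7.4, tested at 200 uM (a higher number here means a more soluble compound, a lower number a less soluble compound), compound 1 (`CCc1cccc(CC)c1NC(=O)c1cc(-c2nc(Nc3ccc(N4CCC(N5CCN(C)CC5)CC4)cc3OC)nc3[nH]ccc23)n(C)n1`) gives 18000 nM and compound 2 (`CCc1cccc(CC)c1N1CCn2cc(-c3nc(Nc4ccc(N5CCC(N6CCN(C)CC6)CC5)cc4OC)nc4[nH]ccc34)cc2C1=O`) gives 6000 nM. Compound 3 (`CCc1cccc(CC)c1N1CCn2cc(-c3nc(Nc4ccc(N5CCC(C(=O)N6CCN(C)CC6)CC5)cc4OC)nc4[nH]ccc34)cc2C1=O`) gives 800 nM, the lowest of the three numbers and beyond the scatter from both others. Compound 4 (`CCc1cccc(CC)c1N1CCn2cc(-c3nc(Nc4ccc(N5CCC(C(=O)N6CC7(CN(C)C7)C6)CC5)cc4OC)nc4[nH]ccc34)cc2C1=O`) differs from compound 3 only in the group on the carbonyl carbon: a group of 8 heavy atoms (6 carbon, 2 nitrogen; 2 four-membered non-aromatic rings with 1 hetero atom each) in place of a group of 7 heavy atoms (5 carbon, 2 nitrogen; one six-membered non-aromatic ring with 2 hetero atoms), on a carbonyl carbon.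

Among the compounds with values here, only one measured step bears on this change, and only indirectly. It is a 7.5-fold lower number from compound 2 to compound 3 (0.88 log units; beyond the scatter), a modest step beyond the scatter, with (4-methylpiperazin-1-yl)carbonyl in place of 4-methylpiperazin-1-yl on a saturated ring carbon. That step introduced the carbonyl, whereas the new change keeps the carbonyl and replaces the group on it. Within the data shown here, no measured pair shows such a replacement, so the data give no direction for this assay, and no step beyond the scatter is expected. The expected result is a 1.3-fold higher number from compound 3 to compound 4 (0.10 log units; within the scatter). For compound 4 the estimated value is 1000 nM, with an expected range from 300 nM to 3500 nM.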

Compound 4, solubility: 180000 nM
Estimate against measurement, compound 4: 180-fold (2.26 log units) below; measured number above the stated range.
By their numbers in this assay, from the lowest: compound 3; then compound 2; then compound 1; then compound 4.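

In this assay, the group on the carbonyl carbon proves to be a strong determinant of the read-out: with the carbonyl kept, replacing 4-methylpiperazin-1-yl with the group of 2 four-membered non-aromatic rings gives a 230-fold higher number from compound 3 to compound 4 (2.35 log units; beyond the scatter). The carbonyl therefore does not by itself hold the number down, as the earlier step alone, a 7.5-fold lower number from compound 2 to compound 3 (0.88 log units; beyond the scatter), might have suggested, since the new group gives a 30-fold higher number from compound 2 to compound 4 (1.48 log units; beyond the scatter). Nothing presented here accounts for the size of this change.

Only these two groups are shown on the carbonyl carbon, so it remains open whether the result depends on the two linked four-membered rings or would extend to other groups at this place. A single azetidine or a morpholine on the same carbonyl carbon would help to separate these possibilities.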